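A few compounds are considered here, and "the series" means these few. Any claim that something is new, unique, unknown or untested is made for them only; others in the source may bear on it.

- Compound 1 `COc1cc(-c2ccnc3cc(-c4c[nH]c5ccccc45)nn23)cc(OC)c1OC`: 40 nM
- Compound 2 `COc1cc(-c2ccnc3cc(-c4cn(C)c5ccccc45)nn23)cc(OC)c1OC`: 185 nM

In a functional assay on B16-F0 cells (Mus musculus) for inhibition, read by CCK-8 assay, with a stated time of 48 h (on this read-out higher numbers stand for weaker inhibition and lower numbers for stronger inhibition), compound 2 gives the higher of the two numbers at 185 nM. Compound 3 `COc1ccc(-c2cc3nccc(-c4cc(OC)c(OC)c(OC)c4)n3n2)cc1` carries 4-methoxyphenyl in place of 1-methyl-1H-indol-3-yl on an aromatic carbon. Within the data shown here, the only measured step, a 4.6-fold higher number from compound 1 to compound 2 (0.67 log units; beyond the scatter), is methyl in place of hydrogen on an aromatic nitrogen. Among the measured compounds shown here, it bears only indirectly, since no measured pair shows this exchange. A step of similar size toward a higher number, meaning weaker inhibition, seems likely, though with wide uncertainty. The expected step is a 2.2-fold higher number from compound 2 to compound 3 (0.33 log units; beyond the scatter). For compound 3 the estimated value is 400 nM, with an expected range of 90 nM to 1800 nM.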

Compound 3, half-maximal inhibitory concentration: 1410 nM
The estimate for compound 3 lay 3.5-fold (0.55 log units) below the measured number, within the range that was stated.
By their numbers in this assay, from the lowest: compound 1; then compound 2; then compound 3.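

In this assay, swapping the 1-methyl-1H-indol-3-yl on this aromatic carbon for 4-methoxyphenyl gives a 7.6-fold higher number from compound 2 to compound 3 (0.88 log units; beyond the scatter), and the same swap against the unmethylated 1H-indol-3-yl gives a 35-fold higher number from compound 1 to compound 3 (1.55 log units; beyond the scatter). Among these three compounds, then, inhibition depends strongly on the group at this carbon, and both indole compounds inhibit more strongly than the 4-methoxyphenyl compound. No available evidence explains these shifts. On these data alone, it remains open how an amine or a longer carbon chain on this carbon would compare with the 1H-indol-3-yl of compound 1.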